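This account rests on a few compounds, and the source may have more. Where it says the series, first, only, none or still open, it means among the compounds named here.

Compound 1 `O=C(Nc1ccc(C(=O)NO)cc1)Nc1ccc(Cl)c(C(F)(F)F)c1` and compound 2 `O=C(/C=C/c1ccc(NC(=O)Nc2ccc(Cl)c(C(F)(F)F)c2)cc1)NO` share one core, and compound 3 `O=C(/C=C/c1ccc(CN2CCc3cc(NC(=O)Nc4ccc(Cl)c(C(F)(F)F)c4)ccc32)cc1)NO` carries a different, larger core; the difference between the two cores is not broken down here. In a functional assay on SK-HEP1 cells (Homo sapiens) for inhibition, read by sulforhodamine B assay, with a stated time of 48 h (a lower number here means a stronger inhibitor, a higher number a weaker inhibitor), compound 1 gives 3800 nM, compound 2 gives 3200 nM and compound 3 gives 3500 nM, all three within the scatter of one another. From compound 2 to compound 1 the change is hydroxycarbamoyl in place of 2-(hydroxycarbamoyl)ethenyl on an aromatic carbon, and the step it made was a 1.2-fold higher number from compound 2 to compound 1 (0.07 log units; within the scatter). Compound 4 `O=C(Nc1ccc2c(c1)CCN2Cc1ccc(C(=O)NO)cc1)Nc1ccc(Cl)c(C(F)(F)F)c1` differs from compound 3 by the same change, (hydroxycarbamoyl in place of 2-(hydroxycarbamoyl)ethenyl on an aromatic carbon). Since the earlier step stayed within the scatter, she expects the step of a 1.1-fold higher number from compound 3 to compound 4 (0.06 log units; within the scatter) in this assay to be of similar size, resting on the measured step of a 1.2-fold higher number from compound 2 to compound 1 (0.07 log units; within the scatter) and on the value of compound 3, 3500 nM. For compound 4 she estimates 4000 nM, with a likely range from 2000 nM to 8000 nM.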

Compound 4, half-maximal inhibitory concentration: 4600 nM
For compound 4 the middle estimate is 1.2-fold (0.06 log units) below the measured one, within the range that was stated.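

On the larger core, the change from 2-(hydroxycarbamoyl)ethenyl to hydroxycarbamoyl made a 1.3-fold higher number from compound 3 to compound 4 (0.12 log units; within the scatter) in this assay. Set beside the earlier step on the other core, the new step does not differ from it: the same change on two cores in this assay, a 1.2-fold higher number (0.07 log units; within the scatter) from compound 2 to compound 1 and a 1.3-fold higher number (0.12 log units; within the scatter) from compound 3 to compound 4, 1.1-fold (0.04 log units) apart, within the scatter of two such steps. In this assay the change therefore carried from one core to the other with no step beyond the scatter, but this rests on two pairs only and does not show that it would hold on any further core or in any other assay.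

The compounds shown leave open how a carboxylic acid in place of hydroxycarbamoyl would read in this assay. They also leave open what a longer chain bearing hydroxycarbamoyl would give on either core.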